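Compound 3: an imidazole in place of a pyridine

A few compounds are considered here, and "the series" means these few. Any claim that something is new, unique, unknown or untested is made for them only; others in the source may bear on it.

Measured in a functional assay on A-375 cells (Homo sapiens) for activation, with a stated time of 3 days; a lower number here means that less compound is needed, a higher number that more compound is needed for the effect:
Compound 1 `O=C(Nc1ccc(-c2cscn2)cc1)C1CCCN(Cc2cccc(C(F)(F)F)c2)C1`: > 20000 nM (a limit of the assay)
Compound 2 `O=C(Nc1ccc(-c2ccncc2)cc1)C1CCCN(Cc2ccc(F)c(F)c2)C1`: 1180 nM

Within the data shown here, compound 2, at 1180 nM, holds the only actual number in this assay. For compound 1 the result is a limit and not a number: > 20000 nM.

The next compound to be tested is compound 3 `O=C(Nc1ccc(-c2c[nH]cn2)cc1)C1CCCN(Cc2ccc(F)c(F)c2)C1`. It carries 1H-imidazol-4-yl in place of pyridin-4-yl on an aromatic carbon of a six-membered aromatic ring of carbon only, para to a large group (1H-imidazol-4-yl in place of pyridin-4-yl on an aromatic carbon). Among the measured compounds shown here, no measured pair of compounds isolates this change, so any expectation here is loose. Compound 1 also carries a five-membered aromatic ring at that place and gave the limit > 20000 nM, but it differs elsewhere too, so it is only weak guidance.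

A moderate move towards needing more compound is expected, with the estimated step being a 2.1-fold higher number from compound 2 to compound 3 (0.33 log units; beyond the scatter). For compound 3 the expected value is 2500 nM, with an estimated range from 500 nM to 12000 nM.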

Compound 3, half-maximal effective concentration: 16000 nM
Compound 3: the middle estimate sits 6.4-fold (0.81 log units) below what was measured; measured number outside the range, above it.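

Among these compounds, this is the only pair in this assay that differs in one place, and it shows that the group on an aromatic carbon of a six-membered aromatic ring of carbon only, para to a large group, matters strongly: 1H-imidazol-4-yl in place of pyridin-4-yl gives a 14-fold higher number from compound 2 to compound 3 (1.13 log units; beyond the scatter). The swap changes several things at once, replacing a six-membered aromatic ring with a five-membered one, adding a hetero atom and bringing in a hydrogen-bond donor, and this single step does not separate them. Little room remains for reading any further loss at this position: the limit of > 20000 nM in this assay, at which 1 of the 3 values shown sits.

The compounds shown leave open whether ring size or the added hydrogen-bond donor accounts for the step, a question that an imidazole carrying a methyl group on its ring nitrogen, or a pyridin-3-yl group, at the same place could help to settle. On these data alone, it also remains open whether a step of this size would recur with the trifluoromethyl group of compound 1 at the other end of the molecule.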